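Cyclohexyl in place of 4-methylbenzyl on the side chain

The source may report more compounds than this note shows. Statements on the series, on what has been measured and on what is new or still open speak of the compounds shown alone.

Three compounds carry numbers in an assay on membranes from Sf9 cells for displacement of a labelled ligand from histamine H2 receptor (Homo sapiens), read by scintillation counting, with a stated time of 60 min; on this read-out lower numbers stand for stronger inhibition and higher numbers for weaker inhibition. Compound 1 `Cc1ccc(CC(C)CNC(=O)/N=C(\N)NCCCc2sc(N)nc2C)cc1` gives 72.4 nM. Compound 3 `CCC(NC(=O)/N=C(\N)NCCCc1sc(N)nc1C)c1ccccc1` gives 63.1 nM, a number within the scatter of compound 1, so the two cannot be told apart. Compound 2 `CCCCCCNC(=O)/N=C(\N)NC1CCc2nc(N)sc2C1`, built on a different core, gives 1120 nM, which stands beyond the scatter from compound 1. Compound 1 thus holds the second highest of the three numbers, close to compound 3 and far from compound 2.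

Compound 4 `Cc1nc(N)sc1CCCN/C(N)=N/C(=O)NCC(C)C1CCCCC1` is not yet measured. It differs from compound 1 in one place: cyclohexyl in place of 4-methylbenzyl on a saturated chain carbon bound to two saturated chain carbons. Among the measured compounds shown here, no step between measured compounds covers this change. A small weakening is expected, near the edge of the scatter, as the estimated step of a 1.8-fold higher number from compound 1 to compound 4 (0.25 log units; within the scatter). For compound 4 the estimate is 130 nM, with a range from 45 nM to 400 nM.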

Compound 4, inhibition constant: 39.8 nM
For compound 4 the middle estimate is 3.3-fold (0.51 log units) above the measured one, and the stated range ends above it.
By their numbers in this assay, from the lowest: compounds 4, 3 and 1 (each within the scatter of the next); then compound 2.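

In this assay, cyclohexyl in place of 4-methylbenzyl on a saturated chain carbon bound to two saturated chain carbons gives a 1.8-fold lower number from compound 1 to compound 4 (0.26 log units; within the scatter) on the shared core. At this position, an aromatic ring of carbon only is thus not needed for a value in this range, and a non-aromatic ring of carbon only serves equally within the scatter. Nothing available explains this result.

Open, on these data alone, is whether a piperidine ring, or a cyclohexyl carrying an amine or a carboxylic acid, would hold the value on this same carbon.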